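Aryl swap on the anilino nitrogen of the shared core

This account rests on a few compounds, and the source may have more. Where it says the series, first, only, none or still open, it means among the compounds named here.

The series shares one core. Compound 1 `Cc1n[nH]c2ccc(-c3nc4cnc(N5CCN(C)CC5)cn4c3Nc3cccc(F)c3)cc12` carries it, and in a functional assay on MV4-11 cells (Homo sapiens) for inhibition, with a stated time of 120 h (a lower number here means a stronger inhibitor, a higher number a weaker inhibitor), compound 1 gives "not determined" (no result reported). Compound 2 `Cc1n[nH]c2ccc(-c3nc4cnc(N5CCN(C)CC5)cn4c3Nc3ccc(I)cc3)cc12` carries it as well, and in this assay compound 2 gives "not determined" (no result reported). Among the compounds with values here, compound 3 `Cc1cc(Br)ccc1Nc1c(-c2ccc3[nH]nc(C)c3c2)nc2cnc(N3CCN(C)CC3)cn12` is the only member with a number: in this assay compound 3 gives 10900 nM, so it stands as a weak inhibitor, and with no second number there is no ranking to speak of. Compound 4 `Cc1n[nH]c2ccc(-c3nc4cnc(N5CCN(C)CC5)cn4c3Nc3ccc(F)cc3Br)cc12` differs from compound 3 by 2-bromo-4-fluorophenyl in place of 4-bromo-2-methylphenyl on a nitrogen on an aromatic ring. Within the data shown here, no step between measured compounds is available to scale this change. The step from compound 3 to compound 4 is expected to be small, a 1.4-fold lower number from compound 3 to compound 4 (0.13 log units; within the scatter), within or barely beyond the usual scatter. Compound 4 is therefore estimated at 8000 nM, with a range from 2500 nM to 30000 nM.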

Compound 4, half-maximal inhibitory concentration: 3830 nM
Beside the measured number, compound 4's estimate is 2.1-fold (0.32 log units) above it; the measured number falls inside the stated range.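

In this assay, the swap to 2-bromo-4-fluorophenyl on a nitrogen on an aromatic ring gives a 2.8-fold lower number from compound 3 to compound 4 (0.45 log units; beyond the scatter), the first measured sign that the series responds to a change at this position. Compound 4 still gives 3830 nM, so the number remains high. No available data explain the step.

Because the bromine position changes and methyl gives way to fluorine in a single step, the two changes cannot be separated. As far as these compounds go, how an aryl ring bearing a methoxy, a nitrile or a carboxylic acid would read here remains open.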